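A few compounds are considered here, and "the series" means these few. Any claim that something is new, unique, unknown or untested is made for them only; others in the source may bear on it.

Compound 1 `CN(C)c1cc2c(NC3CCCCC3)ncnc2cn1`: 199 nM
Compound 2 `C[C@H](Nc1ncnc2cnc(N(C)C)cc12)c1ccccc1`: 1400 nM

In a functional assay on CHO cells for antagonist activity at metabotropic glutamate receptor 1 (Rattus norvegicus), with a stated time of 5 min (a lower number here means a stronger inhibitor, a higher number a weaker inhibitor), compound 1 gives 199 nM, the lower of the two numbers, while compound 2 gives 1400 nM, a gap beyond the usual scatter. Compound 3 `CCCC(C)Nc1ncnc2cnc(N(C)C)cc12` has not yet been measured. It differs from compound 1 in a single place: 1-methylbutyl in place of cyclohexyl on a nitrogen on an aromatic ring. Within the data shown here, no step between measured compounds shows what such an exchange does. A moderate step toward a higher number, a 2.0-fold higher number from compound 1 to compound 3 (0.30 log units; within the scatter), is expected, somewhat beyond the scatter. Compound 3 is therefore estimated at 400 nM, within a range from 150 nM to 1200 nM.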

Compound 3, inhibition constant: 858 nM
The estimate for compound 3 lay 2.1-fold (0.33 log units) below the measured number; low and high end bracket the measured number.
By their numbers in this assay, from the lowest: compound 1; then compounds 3 and 2 (each within the scatter of the next).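

Swapping cyclohexyl for 1-methylbutyl on a nitrogen on an aromatic ring gives a 4.3-fold higher number from compound 1 to compound 3 (0.63 log units; beyond the scatter) in this assay. Among these compounds, this is the first measured exchange in this place, and it shows that the open chain is not an equal replacement for the ring here, at least on the core of compound 1. Nothing measured here explains this step.

Compound 1 and compound 3 cannot separate the loss of the ring from the change in chain shape. Going by these compounds, how a cyclopentyl group or an unbranched n-pentyl chain would fare in this place remains open.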